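Working notes: acetyl(methyl)amino to amino on the saturated ring

A few compounds are considered here, and "the series" means these few. Any claim that something is new, unique, unknown or untested is made for them only; others in the source may bear on it.

Measured so far in an assay on isolated protein for inhibition of protein kinase C theta type (Homo sapiens), read by HTRF; a lower number here means a stronger inhibitor, a higher number a weaker inhibitor:
compound 1, `CO[C@H]1C(=O)C[C@H]2O[C@]1(C)n1c3ccccc3c3c4c(c5c6ccccc6n2c5c31)C(=O)NC4`: 560 nM
compound 2, `CO[C@@H]1[C@H](N(C)C(C)=O)C[C@H]2O[C@]1(C)n1c3ccccc3c3c4c(c5c6ccccc6n2c5c31)C(=O)NC4=O`: 50 nM
compound 3, `CN[C@]1(C(=O)OC)C[C@H]2O[C@]1(C)n1c3ccccc3c3c4c(c5c6ccccc6n2c5c31)C(=O)NC4`: > 2500 nM

Compound 2 gives the lowest of the two numbers in this assay. Compound 1 sits at a higher number, a gap beyond the scatter. For compound 3 this assay reports only a limit, (the limit of > 2500 nM in this assay, at which 1 of the 3 values shown sits), and no number. Going by the values given here, no two of the measured compounds differ in a single place, so no measured step is available within the set.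

Compound 4, `CO[C@@H]1[C@H](N)C[C@H]2O[C@]1(C)n1c3ccccc3c3c4c(c5c6ccccc6n2c5c31)C(=O)NC4=O`, has not yet been measured. It differs from compound 2 at one site: amino in place of acetyl(methyl)amino on a saturated ring carbon. Among the compounds with values here, a single change of this kind gives no measured precedent here, so the expectation rests on compound 2 alone. A small step toward a lower number is expected from compound 2 to compound 4, of size a 2.0-fold lower number from compound 2 to compound 4 (0.30 log units; within the scatter), which may well lie within the scatter of the assay. Compound 4 is therefore estimated at 25 nM in this assay, with a range of 6 nM to 100 nM.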

Compound 4, half-maximal inhibitory concentration: 36 nM
Compound 4: the middle estimate sits 1.4-fold (0.16 log units) below what was measured; the measured number falls inside the stated range.
By their numbers in this assay, from the lowest: compounds 4 and 2 (each within the scatter of the next); then compound 1. At a limit, above all of these: compound 3.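

In this assay the replacement of acetyl(methyl)amino by amino on the saturated ring carbon gives a 1.4-fold lower number from compound 2 to compound 4 (0.14 log units; within the scatter) and so separates the two groups by no more than the usual scatter. Going from 5 heavy atoms to 1, and from 0 hydrogen-bond donors to 1, at this carbon therefore leaves the reading in this assay effectively unchanged, something compound 1 and compound 3 did not show, as each differs from compound 2 in more than one place. Nothing measured here gives a cause for this step or says which part of the departing group, if any, matters.

Open, from the compounds shown here alone, is how far this carbon accepts other groups: an acetylamino group, a dimethylamino group, a longer chain on the nitrogen or a carboxylic acid would each test it beyond these two end points. Also open, going by these compounds, is whether the same replacement reads alike on the core of compound 1, and whether it depends on the methoxy group on the neighbouring ring atom.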